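A few compounds are considered here, and "the series" means these few. Any claim that something is new, unique, unknown or untested is made for them only; others in the source may bear on it.

Measured compounds:
- compound 1, `CC(C)(C)C[C@H](N)C(=O)Nc1cc2cc[nH]c(=O)c2cc1Cl`: "not determined" (no result reported) in a functional assay (aorta) with Rattus norvegicus as the target; a higher number here means that more compound is needed for the effect, a lower number that less compound is needed
- compound 2, `N[C@H]1CC[C@@H](C(=O)Nc2cc3cc[nH]c(=O)c3cc2Cl)CC1`: 180 nM
- compound 3, `CC(C)C[C@H](N)C(=O)Nc1cc2cc[nH]c(=O)c2cc1Cl`: "not determined" (no result reported) in this assay

Compound 3 therefore stands nowhere on the numbers: it has no value in this assay, and compound 1 shares that blank, so only compound 2 gives an anchor for the series.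

Compound 4, `NCC(=O)Nc1cc2cc[nH]c(=O)c2cc1Cl`, is reached from compound 3 by hydrogen in place of isobutyl on a saturated chain carbon bound to an amine nitrogen and a carbonyl carbon. For the measured compounds named here, no step between measured compounds is known, so the size of this step in this assay is open; the expectation is a step toward more compound needed, beyond the scatter.

With compound 2 as the only reference, compound 4 is expected at 1000 nM, within 200 nM to 5000 nM.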

Compound 4, half-maximal effective concentration: 2500 nM
Beside the measured number, compound 4's estimate is 2.5-fold (0.40 log units) below it, and the stated range covers the measured number.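

In this assay the series now has its first readable step, a 14-fold higher number from compound 2 to compound 4 (1.14 log units; beyond the scatter) with aminomethyl in place of 4-aminocyclohexyl on a carbonyl carbon. The group on this carbonyl carbon therefore moves the number well beyond the scatter, and the ring-bearing compound 2 needs less compound than the open-chain compound 4. No measured finding accounts for this step.

Steps from compound 1 and compound 3 to compound 4 cannot be read, leaving isobutyl against hydrogen on the saturated chain carbon unresolved. Also open, as far as these compounds go, is whether a longer chain between amine and carbonyl recovers the number of compound 2.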